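This account rests on a few compounds, and the source may have more. Where it says the series, first, only, none or still open, it means among the compounds named here.

Among the compounds with values here, compound 2 `Nc1nc(CC2CCCCC2)c(-c2ccccc2Br)n1CC(=O)Nc1ccccc1` stands highest of the two numbers so far in a functional assay on MIA PaCa-2 cells (Homo sapiens) for antiproliferative activity, read by MTT assay, with a stated time of 48 h (a higher number here means a weaker inhibitor, a lower number a stronger inhibitor), where compound 2 gives 89000 nM. Its nearest neighbour, compound 1 `CCCCCCc1nc(N)n(CC(=O)Nc2ccccc2)c1-c1ccccc1Br`, gives 8600 nM in this assay. Within the data shown here, the only measured step, a 10-fold higher number from compound 1 to compound 2 (1.01 log units; beyond the scatter), was large, showing that this part of the molecule matters. Compound 3 `Cc1ccc(Cc2nc(N)n(CC(=O)Nc3ccccc3)c2-c2ccccc2Br)cc1` carries 4-methylphenyl in place of cyclohexyl on a saturated chain carbon bound to an aromatic carbon. Among the measured compounds shown here, no measured step shows what an aromatic ring does here, so only a modest move is estimated for compound 3, a 1.8-fold lower number from compound 2 to compound 3 (0.25 log units; within the scatter). Compound 3 is therefore expected to give about 50000 nM in this assay, within a range of 10000 nM to 200000 nM.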

Compound 3, half-maximal inhibitory concentration: 9200 nM
Compound 3: the middle estimate sits 5.4-fold (0.74 log units) above what was measured; measured number below the stated range.
By their numbers in this assay, from the lowest: compounds 1 and 3 (each within the scatter of the next); then compound 2.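

In this assay the change from cyclohexyl to 4-methylphenyl gives a 9.7-fold lower number from compound 2 to compound 3 (0.99 log units; beyond the scatter) and so shows that the weak result with cyclohexyl does not extend to every six-membered ring on this saturated chain carbon. The change from pentyl to 4-methylphenyl gives a 1.1-fold higher number from compound 1 to compound 3 (0.03 log units; within the scatter) and so leaves the open chain and the aromatic ring level here. Nothing available explains these results. Open, from the compounds shown here alone, is what the methyl of 4-methylphenyl contributes, and how an unsubstituted phenyl, a methoxy group or a longer chain would compare.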